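The source may hold more compounds than are shown below. What is called first, only, known or untested is meant among the compounds shown, and "the series" means these compounds.

Series notes. Compound 1 `O=C(/C(=C\c1ccccc1OCc1ccccc1)SCc1ccc(F)cc1)c1ccc(Cl)cc1`, compound 2 `Cc1ccc(CS(=O)(=O)/C(=C/c2ccccc2OCc2ccccc2)C(=O)c2ccc(Cl)cc2)cc1` and compound 3 `COc1ccc(S/C(=C/c2ccccc2OCc2ccccc2)C(=O)c2ccc(Cl)cc2)cc1` share one core and differ only in the group carried on the double-bonded chain carbon bound to a carbonyl carbon and a double-bonded chain carbon. In a functional assay on DU-145 cells (Homo sapiens) for inhibition, read by trypan blue exclusion, with a stated time of 96 h (a lower number here means a stronger inhibitor of growth, a higher number a weaker inhibitor of growth), compound 1 gives 1000 nM, compound 2 gives 1000 nM and compound 3 gives 1000 nM. Compound 3 thus stands level with both of its neighbours; it is nearest to compound 1 and furthest from compound 2 only in the formal sense, as neither gap reaches beyond the scatter.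

Compound 4 `COc1ccc(S(=O)(=O)/C(=C/c2ccccc2OCc2ccccc2)C(=O)c2ccc(Cl)cc2)cc1` is the next member and is not yet measured. Its difference from compound 3: (4-methoxyphenyl)sulfonyl in place of (4-methoxyphenyl)sulfanyl on a double-bonded chain carbon bound to a carbonyl carbon and a double-bonded chain carbon. Going by the values given here, two measured steps bear on a change from sulfanyl to sulfonyl at this place: no change at the digits printed from compound 1 to compound 2 (within the scatter), where the group on the sulfur changed as well, and the reverse direction, no change at the digits printed from compound 2 to compound 3 (within the scatter), where the group on the sulfur also changed. The third step, no change at the digits printed from compound 1 to compound 3 (within the scatter), likewise stayed flat. Among the compounds with values here, no measured step has moved the read-out beyond the scatter, so no step beyond the scatter is expected for no change at the digits printed from compound 3 to compound 4 (within the scatter). Compound 4 is accordingly estimated at 1000 nM, within a range from 500 nM to 2500 nM.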

Compound 4, concentration for 50% growth inhibition: 1000 nM
Estimate against measurement, compound 4: no gap at the digits printed; measured number inside the range.
By their numbers in this assay, from the lowest: compounds 1, 2, 3 and 4 (each within the scatter of the next).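

Going by these compounds alone, with the 4-methoxyphenyl group held fixed, the exchange of (4-methoxyphenyl)sulfanyl for (4-methoxyphenyl)sulfonyl gives the first clean reading of the sulfur change at this place in this assay, with no change at the digits printed from compound 3 to compound 4 (within the scatter) and no second alteration on the sulfur to confound it. With the sulfonyl held fixed, the exchange of 4-methylbenzyl for 4-methoxyphenyl on the sulfonyl sulfur gives no change at the digits printed from compound 2 to compound 4 (within the scatter), and the combined exchange of (4-fluorobenzyl)sulfanyl for (4-methoxyphenyl)sulfonyl gives no change at the digits printed from compound 1 to compound 4 (within the scatter), so the group on the sulfur and the sulfur change each leave the read-out flat, alone and together, across these four compounds. No supporting data are available to account for this flat read-out.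

The compounds shown leave open whether a group of another kind on the double-bonded chain carbon bound to a carbonyl carbon and a double-bonded chain carbon, such as an amine, a carboxylic acid or a longer chain, would move the read-out beyond the scatter. Going by these compounds, the rest of the shared core is the same in all four compounds, so how the read-out responds to changes there also remains open.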